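This account rests on a few compounds, and the source may have more. Where it says the series, first, only, none or still open, it means among the compounds named here.

Measured compounds in a functional assay for activation of Alpha-1D adrenergic receptor (Homo sapiens), read by calcium flux; on this read-out lower numbers stand for an effect already at smaller amounts and higher numbers for an effect only at larger amounts of compound:
compound 1, `c1cnc(-c2ccccc2OCC2=NCCN2)nc1`: compound 1 gives < 100000 nM, a limit of the assay and not a number.
compound 2, `c1ccc(-c2ccsc2)c(OCC2=NCCN2)c1`: compound 2 gives 12.6 nM.
compound 3, `c1ccc(-c2ccns2)c(OCC2=NCCN2)c1`: compound 3 gives 25.1 nM.

Compound 3 holds the higher of the two readable numbers; its nearest neighbour is compound 2, and the step of a 2.0-fold higher number from compound 2 to compound 3 (0.30 log units; within the scatter) lies within the scatter, so the two cannot be ordered. The value of compound 1 is a limit (the limit of < 100000 nM in this assay, at which 1 of the 3 values shown sits), and so the steps a step that the limit leaves unreadable from compound 1 to compound 2 and a step that the limit leaves unreadable from compound 1 to compound 3 have no readable size.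

Compound 4, `c1ccc(-c2ncc[nH]2)c(OCC2=NCCN2)c1`, is not yet measured. It differs from compound 3 in one place: 1H-imidazol-2-yl in place of 1,2-thiazol-5-yl on an aromatic carbon. Of the measured steps only the exchange of one five-membered ring for another, a 2.0-fold higher number from compound 2 to compound 3 (0.30 log units; within the scatter), resembles this change, and it stayed within the scatter. Among the compounds with values here, no measured step brings in a hydrogen-bond donor, so that part of the change is untested. The expectation is a moderate shift toward a higher number, a 4.0-fold higher number from compound 3 to compound 4 (0.60 log units; beyond the scatter), with wide uncertainty. Compound 4 is therefore estimated at 100 nM, in the range 15 nM to 800 nM.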

Compound 4, half-maximal effective concentration: < 100000 nM
Compound 4: no number, only a limit; the forecaster's own chance of this, stated with the estimate: 15%; the middle value is on the limit's open side.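

In this assay compound 4 gives < 100000 nM, a limit of the assay and not a number. Its steps from compound 1, compound 2 and compound 3 cannot be read. The compounds shown leave open how large the change from 1,2-thiazol-5-yl to 1H-imidazol-2-yl is.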